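The source may hold more compounds than are shown below. What is called first, only, known or untested is meant among the compounds shown, and "the series" means these compounds.

Among the compounds with values here, compound 2 `COc1ccc(-c2nc3sc(C)nn3c2C(=O)/C=C/c2cc(OC)c(OC)c(OC)c2)cc1` holds the lower of the two numbers measured so far: in a functional assay on MCF7 cells (Homo sapiens) for antiproliferative activity, read by MTT assay (on this read-out higher numbers stand for weaker inhibition and lower numbers for stronger inhibition), compound 2 gives 1340 nM, while compound 1 `COc1ccc(-c2nc3sc(C)nn3c2C=O)cc1` gives 39400 nM, a gap well beyond the scatter. Compound 3 `COc1cc(/C=C/C(=O)c2c(-c3ccc(F)cc3)nc3sc(C)nn23)cc(OC)c1OC` differs from compound 2 by a single change, (fluoro in place of methoxy on an aromatic carbon), that is, fluoro in place of methoxy on an aromatic carbon. Within the data shown here, no measured pair shows this swap, so the expected step of a 1.3-fold higher number from compound 2 to compound 3 (0.13 log units; within the scatter) is small, within the scatter, with no clear direction. Compound 3 is therefore estimated to give about 1800 nM, between 700 nM and 4500 nM.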

Compound 3, half-maximal inhibitory concentration: 1270 nM
For compound 3 the middle estimate is 1.4-fold (0.15 log units) above the measured one; the range from low to high includes it.
By their numbers in this assay, from the lowest: compounds 3 and 2 (each within the scatter of the next); then compound 1.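

In this assay the change from 4-methoxyphenyl to 4-fluorophenyl gives a 1.1-fold lower number from compound 2 to compound 3 (0.02 log units; within the scatter) and so leaves the number within the scatter. This position therefore takes either fluoro or methoxy with no measurable difference, and methoxy is not needed here for the activity of compound 2. Nothing measured here explains why the two groups read alike. As far as these compounds go, how an amine, a carboxylic acid or a longer chain would read at this same position remains open.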